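Morpholine amide in place of diethylamide on compound 1

The compounds below may be only part of what the source reports. "The series", "measured", "known", "first", "only" and "open" are said of these compounds alone.

Compound 1 `CCN(CC)C(=O)[C@@H](NC(=O)[C@H](CC(=O)O)NC(=O)CCCOc1ccc(C(=N)N)cc1)C(C)C` gives 250 nM in a functional assay with Homo sapiens as the target, in the presence of a further agent that is not named here; a lower number here means a stronger inhibitor, a higher number a weaker inhibitor. Among the three compounds measured it holds the second highest number: compound 3 `CC(C)[C@H](NC(=O)[C@H](CC(=O)O)NC(=O)CCCOc1ccc(C(=N)N)cc1)C(=O)O`, with 100 nM, lies nearest, and compound 2 `CC(C)CNC(=O)[C@H](CC(=O)O)NC(=O)CCCOc1ccc(C(=N)N)cc1`, with 1200 nM, lies furthest. Compound 4 `CC(C)[C@H](NC(=O)[C@H](CC(=O)O)NC(=O)CCCOc1ccc(C(=N)N)cc1)C(=O)N1CCOCC1` has not yet been measured; it differs from compound 1 in one place, (morpholin-4-yl in place of diethylamino on a carbonyl carbon). Going by the values given here, two measured steps bear on this change. Removing the whole diethylcarbamoyl group gives a 4.8-fold higher number from compound 1 to compound 2 (0.68 log units; beyond the scatter), while exchanging the diethylamino for hydroxy on the same carbonyl carbon gives a 2.5-fold lower number from compound 1 to compound 3 (0.40 log units; beyond the scatter). Both steps touch the same end of compound 1, shift the number only modestly, and run in opposite directions, and each of them does away with the tertiary amide altogether. The change to compound 4 keeps a tertiary amide and merely exchanges one amine for another, so a step no larger than the scatter is expected, with no clear lean in either direction. Compound 4 is therefore expected to give about 250 nM in this assay, within a range from 100 nM to 600 nM, which means no change at the digits printed from compound 1 to compound 4 (within the scatter).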

Compound 4, half-maximal inhibitory concentration: 79 nM
For compound 4 the middle estimate is 3.2-fold (0.50 log units) above the measured one; the whole stated range lies above it.
By their numbers in this assay, from the lowest: compounds 4 and 3 (each within the scatter of the next); then compound 1; then compound 2.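

In this assay, the amine on this carbonyl carbon turns out to matter even when the tertiary amide is kept: morpholin-4-yl in place of diethylamino gives a 3.2-fold lower number from compound 1 to compound 4 (0.50 log units; beyond the scatter). The free carboxy end is also not needed for the lowest numbers in this set, as the exchange of hydroxy for morpholin-4-yl gives a 1.3-fold lower number from compound 3 to compound 4 (0.10 log units; within the scatter), so the two groups cannot be told apart on this carbonyl carbon. The step of a 15-fold lower number from compound 2 to compound 4 (1.18 log units; beyond the scatter) shows that a (morpholin-4-yl)carbonyl group on the saturated chain carbon reaches the same large kind of drop in the number as carboxy does there, while compound 1, with diethylcarbamoyl in that place, goes against any reading that all such groups serve equally well.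

Nothing shown gives a measured reason for the difference between the morpholin-4-yl and diethylamino amides. The compounds also do not separate the ring from its oxygen, and a piperidin-1-yl group on the same carbonyl carbon would bear on that question.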